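Swapping Chloro for Methyl on an Adenosine Receptor Ligand

The source may report more compounds than this note shows. Statements on the series, on what has been measured and on what is new or still open speak of the compounds shown alone.

Compound 1 `CCn1c(=O)c2nc(-c3cccc(S(=O)(=O)NCCN(C)C)c3)[nH]c2n(CC)c1=O`: 29.4 nM
Compound 2 `Cn1c(=O)c2nc(-c3ccc(Cl)cc3)[nH]c2n(C)c1=O`: 0.8 nM
Compound 3 `CCCn1c(=O)c2nc(-c3ccc(S(=O)(=O)NCCCC(=O)OCC)cc3)[nH]c2n(CCC)c1=O`: 0.24 nM

In an assay for binding affinity to adenosine receptor A1 (Bos taurus) (on this read-out lower numbers stand for stronger inhibition and higher numbers for weaker inhibition), compound 2 gives 0.8 nM, the second highest of the three numbers. Compound 3 gives a lower number than compound 2, a gap beyond the scatter, and compound 1 gives a far higher number, also beyond the scatter.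

Compound 4 `Cc1ccc(-c2nc3c(=O)n(C)c(=O)n(C)c3[nH]2)cc1` has not yet been measured. It differs from compound 2 by methyl in place of chloro on an aromatic carbon, para to a large group. Among the measured compounds shown here, no pair of measured compounds shows this exchange, so no step can be read off. The exchange trades one small group for another of like size, as the counted difference shows. The step is expected to be small, toward a slightly higher number, or none beyond the scatter. The expected value for compound 4 is 1.5 nM, with a range from 0.5 nM to 5 nM. This estimate means a step of a 1.9-fold higher number from compound 2 to compound 4 (0.27 log units; within the scatter) that is expected to stay within the scatter.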

Compound 4, half-maximal inhibitory concentration: 0.8 nM
The estimate for compound 4 lay 1.9-fold (0.27 log units) above the measured number; the measured number falls inside the stated range.
By their numbers in this assay, from the lowest: compound 3; then compounds 2 and 4 (each within the scatter of the next); then compound 1.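

In this assay methyl in place of chloro on an aromatic carbon, para to a large group, brings no change at the digits printed from compound 2 to compound 4 (within the scatter) and so the two groups serve equally well at this place on the shared core. Among the compounds shown here, this is the first comparison here that isolates a single change, since the earlier compounds differ from one another in several places. Nothing measured here explains why the exchange leaves the number in place.

On these data alone, how an amine, a carboxylic acid or a longer chain would fare at this same place remains open. As far as these compounds go, it is also open whether methyl and chloro would match as closely on a core carrying other groups.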